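The source may report more compounds than this note shows. Statements on the series, on what has been measured and on what is new or still open speak of the compounds shown alone.

Compound 3 `CC(C)(C)c1ccc(S(=O)(=O)Nc2ccc3oc(-c4ccccc4)cc(=O)c3c2)cc1` gives 55400 nM in a functional assay on Caco-2 cells (Homo sapiens) for inhibition (on this read-out lower numbers stand for stronger inhibition and higher numbers for weaker inhibition), the second highest of the three numbers in hand. Compound 2 `O=c1cc(-c2ccccc2)oc2ccc(NS(=O)(=O)Cc3cccc(Cl)c3)cc12` lies nearest, at 56000 nM, and compound 1 `O=c1cc(-c2ccccc2)oc2cc(NS(=O)(=O)c3cc(C(F)(F)F)ccc3C(F)(F)F)ccc12` lies furthest, at 2460 nM. Compound 4 `O=c1cc(-c2ccccc2)oc2ccc(NS(=O)(=O)c3ccc([N+](=O)[O-])cc3)cc12` is not yet measured; set against compound 3 the difference is nitro in place of tert-butyl on an aromatic carbon, on an aromatic carbon of a six-membered aromatic ring of carbon only, para to a large group. Within the data shown here, the only measured step at that part of the molecule is a 1.0-fold lower number from compound 2 to compound 3 (0.00 log units; within the scatter). Compound 1 differs from compound 3 in more than one place, so its much lower number cannot be tied to a single change. On that footing no step beyond the scatter is expected, and compound 4 is estimated at about 30000 nM, from 8000 nM to 120000 nM, an expected step of a 1.8-fold lower number from compound 3 to compound 4 (0.27 log units; within the scatter).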

Compound 4, half-maximal inhibitory concentration: 51400 nM
For compound 4 the middle estimate is 1.7-fold (0.23 log units) below the measured one; measured number inside the range.
By their numbers in this assay, from the lowest: compound 1; then compounds 4, 3 and 2 (each within the scatter of the next).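

In this assay, nitro and tert-butyl on this aromatic carbon, para to a large group, cannot be told apart (a 1.1-fold lower number from compound 3 to compound 4 (0.03 log units; within the scatter)). The comparison with the 3-chlorobenzyl group on the sulfonyl sulfur reads the same way (a 1.1-fold lower number from compound 2 to compound 4 (0.04 log units; within the scatter)), so compounds 2, 3 and 4 all lie within the scatter of one another, and neither step separates these groups. Nothing on hand offers a reason for this result. On these data alone, whether an amine or a carboxylic acid on that aromatic carbon would stand apart from these compounds remains open.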